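Phenylpiperazine series: oxazolyl replacing phenolic hydroxy

A few compounds are considered here, and "the series" means these few. Any claim that something is new, unique, unknown or untested is made for them only; others in the source may bear on it.

Three compounds have numbers in a functional assay for antagonist activity at Alpha-1A adrenergic receptor (Oryctolagus cuniculus); a lower number here means tighter binding, a higher number weaker binding. Compound 1 `COc1ccccc1N1CCN(CCCNc2ccncc2C(=O)N(C)C)CC1` gives 12.6 nM. Compound 2 `COc1ccccc1N1CCN(CCCSc2ccccc2C(=O)N(C)C)CC1` gives 2 nM. Compound 3 `CN(C)C(=O)c1cccnc1NCCCN1CCN(c2ccccc2O)CC1` gives 5.01 nM, the second highest of the three numbers; its nearest neighbour is compound 2, whose number is lower by a margin beyond the usual scatter, and its furthest is compound 1, whose number is higher by a similar margin, also beyond the scatter. No two of these compounds differ in a single place, so no step between measured compounds can be read off.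

Compound 4 `CN(C)C(=O)c1cccnc1NCCCN1CCN(c2ccccc2-c2ncco2)CC1` is not yet measured. It differs from compound 3 by 1,3-oxazol-2-yl in place of hydroxy on an aromatic carbon. The hydroxy of compound 3 and the methoxy of compound 1 sit on different cores, so the change cannot be judged against a measured step. A step within the scatter or a modest weakening is expected in this assay, as a 1.6-fold higher number from compound 3 to compound 4 (0.20 log units; within the scatter). For compound 4 the estimate is 8 nM, with a range of 2 nM to 30 nM, anchored on compound 3 because it gives 5.01 nM with the same core.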

Compound 4, dissociation constant: 0.316 nM
Compound 4: the middle estimate sits 25-fold (1.40 log units) above what was measured, outside the stated range (below it).
By their numbers in this assay, from the lowest: compound 4; then compound 2; then compound 3; then compound 1.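

In this assay, this aromatic carbon on the shared core accepts a five-membered aromatic ring: 1,3-oxazol-2-yl in place of hydroxy gives a 16-fold lower number from compound 3 to compound 4 (1.20 log units; beyond the scatter), a large step. Among the compounds shown here, the hydrogen-bond donor of the hydroxy is therefore not required here for a low number, at least in this pair, and the earlier compounds could not show this because none of them formed a single-place pair. No measurement shown accounts for the size of the step.

On these data alone, whether the gain depends on the 1,3-oxazol-2-yl itself remains open, and a phenyl, a thiazol-2-yl or an amino group at the same place on the same core would test this. For the compounds shown here, compound 1 and compound 2 differ from compound 4 in more than one place, so no steps to them can be read.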